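Methyl on the Aromatic Nitrogen in Two Parallel Pairs

The compounds below may be only part of what the source reports. "The series", "measured", "known", "first", "only" and "open" are said of these compounds alone.

Compound 1 `COc1cc(C(=O)/C=C/c2c[nH]c3ccccc23)cc(SC)c1OC` opens the first pair. In a functional assay on MCF7 cells (Homo sapiens) for antiproliferative activity, read by MTT assay, with a stated time of 48 h (a higher number here means a weaker inhibitor, a lower number a stronger inhibitor), compound 1 gives 186 nM. Compound 3 `COc1cc(C(=O)/C=C/c2cn(C)c3ccccc23)cc(SC)c1OC` carries methyl in place of hydrogen on an aromatic nitrogen and in this assay compound 3 gives 102 nM, a move of a 1.8-fold lower number from compound 1 to compound 3 (0.26 log units; within the scatter).

Compound 2 `COc1cc(C(=O)/C(C)=C/c2c[nH]c3ccccc23)cc([Se]C)c1OC` rests on a different core; the difference between the two cores is not broken down here. In this assay compound 2 gives 59 nM. Its gap to compound 3 is within the scatter, while its gap to compound 1 lies beyond it.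

Compound 4 `COc1cc(C(=O)/C(C)=C/c2cn(C)c3ccccc23)cc([Se]C)c1OC` is not yet measured. It differs from compound 2 by methyl in place of hydrogen on an aromatic nitrogen, the same change that turned compound 1 into compound 3, made at the same place. Because that step was a 1.8-fold lower number from compound 1 to compound 3 (0.26 log units; within the scatter), a step of similar size and direction is expected for compound 4, namely a 1.6-fold lower number from compound 2 to compound 4 (0.19 log units; within the scatter). The basis is a single measured pair on another core, so the range is kept wide. For compound 4 the estimate in this assay is 38 nM, with 15 nM to 110 nM as its range.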

Compound 4, half-maximal inhibitory concentration: 77 nM
Compound 4: the middle estimate sits 2.0-fold (0.31 log units) below what was measured; low and high end bracket the measured number.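

In this assay, methyl in place of hydrogen on an aromatic nitrogen gives a 1.3-fold higher number from compound 2 to compound 4 (0.12 log units; within the scatter), and the step on the core of compound 1 does not separate from it: the same change on two cores in this assay, a 1.8-fold lower number (0.26 log units; within the scatter) from compound 1 to compound 3 and a 1.3-fold higher number (0.12 log units; within the scatter) from compound 2 to compound 4, 2.4-fold (0.38 log units) apart, within the scatter of two such steps. On these two pairs, the change carries from one core to the other without a difference that can be told from the scatter, and neither step on its own lies beyond the scatter. This does not show that the two steps are identical, that the change moves the number in a set direction, or that the result would hold on any further core, since two small steps of opposite sign settle none of these points.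

Open, as far as these compounds go, is whether a larger group on that aromatic nitrogen, such as an ethyl, a longer chain or a chain ending in a carboxylic acid, would move the number beyond the scatter. Also open is how the methyl step behaves on a core that carries only one of the differences between the two cores shown.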